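Chloro for Methoxy on the Shared Core of Compound 1

This account rests on a few compounds, and the source may have more. Where it says the series, first, only, none or still open, it means among the compounds named here.

Compound 1 `COc1cccc(/C=C/C(=O)Nc2nc3ccccc3c(=O)s2)c1` carries a 3-methoxyphenyl on the shared core. In an assay on CHO cells for displacement of a labelled ligand from adenosine receptor A3 (Homo sapiens), read by scintillation counting, with a stated time of 60 min (a higher number here means a weaker inhibitor, a lower number a stronger inhibitor), compound 1 gives > 1000 nM, which is a limit of the assay and not a number. Compound 2 `COc1cccc(/C=C/CC(=O)Nc2nc3ccccc3c(=O)s2)c1` differs from compound 1 in more than one place, and the difference between the two cores is not broken down here. In this assay compound 2 gives 115 nM. Compound 3 `O=C(C/C=C/c1cccc(Cl)c1)Nc1nc2ccccc2c(=O)s1` is compound 2 with chloro in place of methoxy on an aromatic carbon. In this assay compound 3 gives > 1000 nM, again a limit of the assay rather than a number. The step of an at least 8.6-fold higher number from compound 2 to compound 3 (0.93 log units; beyond the scatter) carries the change from a measured number to a limit.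

Compound 4 `O=C(/C=C/c1cccc(Cl)c1)Nc1nc2ccccc2c(=O)s1` is compound 1 with the same change, (chloro in place of methoxy on an aromatic carbon), at a place described in the same words. Two of the three values already sit at the limit of > 1000 nM in this assay, at which 2 of the 3 values shown sit. Compound 4 is expected to stay at that limit, a step that the limit leaves unreadable from compound 1 to compound 4. This expectation rests on compound 1, whose value > 1000 nM is a limit. It rests too on the step of an at least 8.6-fold higher number from compound 2 to compound 3 (0.93 log units; beyond the scatter). The estimate for compound 4 is 3000 nM, expected between 1000 nM and 20000 nM, and most likely to be reported as a limit.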

Compound 4, inhibition constant: > 1000 nM
Compound 4 was reported as a limit; the forecaster's own chance of this, stated with the estimate: 85%; the middle value does not contradict the limit.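

No new step can be read from compound 1 to compound 4, since both compounds are reported only as limits in this assay, not as numbers: the limit of > 1000 nM in this assay, at which 3 of the 4 values shown sit.

The compounds shown leave open whether chloro in place of methoxy changes the value on the core of compound 1 as it does on the core of compound 2.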